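Adding a Chlorine to the Ring Amine Substituent

The source may report more compounds than this note shows. Statements on the series, on what has been measured and on what is new or still open speak of the compounds shown alone.

Of the compounds shown here, three sharing one core have been measured in a functional assay on CHO cells with adenosine receptor A1 (Homo sapiens) as the target, read by cAMP accumulation and immunoassay, with a stated time of 6 min, tested at 1 uM; a lower number here means a stronger effect, a higher number a weaker effect of the compound at the concentration tested. Compound 1 `Nc1scc(CN2CCN(C3CCCCCC3)CC2)c1C(=O)c1ccc(Cl)cc1` gives 3.7%, compound 2 `Nc1scc(CN2CCN(c3cccc4ccccc34)CC2)c1C(=O)c1ccc(Cl)cc1` gives 2.9%, and compound 3 `Nc1scc(CN2CCN(c3cccc(F)c3)CC2)c1C(=O)c1ccc(Cl)cc1` gives -86%, the lowest of the three numbers. The step of a number 0.8 percentage points lower from compound 1 to compound 2 (within the scatter) is small, whereas a number 89.7 percentage points lower from compound 1 to compound 3 (beyond the scatter) and a number 88.9 percentage points lower from compound 2 to compound 3 (beyond the scatter) are large drops, both ending at compound 3.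

Compound 4 `Nc1scc(CN2CCN(c3ccc(F)c(Cl)c3)CC2)c1C(=O)c1ccc(Cl)cc1` has not been measured. It differs from compound 3 in one place: 3-chloro-4-fluorophenyl in place of 3-fluorophenyl on an amine nitrogen in a ring. For the measured compounds named here, no measured step tests the addition of a chlorine to a fluorophenyl; the two large drops only show that the 3-fluorophenyl group lies far below the cycloheptyl and naphthalen-1-yl groups. Compound 4 keeps a fluorophenyl. Its step of a number 16 percentage points higher from compound 3 to compound 4 (beyond the scatter) is expected to lie within the scatter or only modestly above it, given that compound 3 gives -86%. Compound 4 is therefore estimated to give -70%, within a range from -105% to -25%.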

Compound 4, a percentage reported as activity, at one concentration (the size of the read-out at that concentration, not a potency): -60%
Beside the measured number, compound 4's estimate is 10 percentage points below it, within the range that was stated.
By their numbers in this assay, from the lowest: compound 3; then compound 4; then compounds 2 and 1 (each within the scatter of the next).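

In this assay, the step is a number 26 percentage points higher from compound 3 to compound 4 (beyond the scatter), so a change confined to the substituents on this aromatic ring, with the ring itself kept, is enough to shift the read-out at this position. Even so, the 3-chloro-4-fluorophenyl group stays far from the cycloheptyl and naphthalen-1-yl groups, with a number 62.9 percentage points lower from compound 2 to compound 4 (beyond the scatter) and a number 63.7 percentage points lower from compound 1 to compound 4 (beyond the scatter), so the earlier large gap narrows but remains. No measured evidence on the reason for this shift is available.

The group names show that the change is more than one added chlorine, as the fluorine's number also differs, so the step cannot be assigned to either halogen alone. A 3-chlorophenyl or 4-fluorophenyl group on the same nitrogen would separate these two changes, while an unsubstituted phenyl group would show what the halogens contribute together.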